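From benzyl to cyclohexyl on the amine nitrogen

The source may report more compounds than this note shows. Statements on the series, on what has been measured and on what is new or still open speak of the compounds shown alone.

- compound 1 `O=C1C(Nc2ccc(Br)cc2)=CC(=O)c2c1nc1n2[C@H]2OC[C@@H](O)[C@H]2OC1`: 5220 nM
- compound 2 `O=C1C(NC2CC2)=CC(=O)c2c1nc1n2[C@H]2OC[C@@H](O)[C@H]2OC1`: > 16000 nM, a limit of the assay
- compound 3 `O=C1C(NCc2ccccc2)=CC(=O)c2c1nc1n2[C@H]2OC[C@@H](O)[C@H]2OC1`: 11000 nM

In a functional assay on HeLa cells (Homo sapiens) for inhibition, read by sulforhodamine B assay (a lower number here means a stronger inhibitor, a higher number a weaker inhibitor), compound 3 gives 11000 nM, the higher of the two actual numbers, and the other is set apart by a 2.1-fold higher number from compound 1 to compound 3 (0.32 log units; beyond the scatter). Compound 2 has only a limit, > 16000 nM, and no actual number.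

Compound 4 `O=C1C(NC2CCCCC2)=CC(=O)c2c1nc1n2[C@H]2OC[C@@H](O)[C@H]2OC1` carries cyclohexyl in place of benzyl on an amine nitrogen.

Within the data shown here, no measured step makes this exact swap. The step of an at least 3.0-fold higher number from compound 1 to compound 2 (0.48 log units; beyond the scatter) starts from 4-bromophenyl, as does the gap already given for compound 3, so both offer only indirect guidance. Compound 2 is the closest guide, since cyclopropyl is also a non-aromatic ring, and its step is an at least 1.4-fold lower number from compound 2 to compound 3 (0.16 log units; that floor lies within the scatter). This points to a weak result with little separation from compound 3.

In this assay the expected change is a 1.3-fold higher number from compound 3 to compound 4 (0.10 log units; within the scatter), which is no step beyond the scatter. For compound 4 the estimated value is 14000 nM, with an expected range from 7000 nM to 26000 nM.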

Compound 4, half-maximal inhibitory concentration: > 16000 nM
Compound 4: a limit, no number; the forecaster's own chance of this, stated with the estimate: 40%; middle value at least 1.1-fold (0.05 log units) from the limit.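

Compound 4 joins compound 2 at a limit of the assay rather than an actual number: the limit of > 16000 nM in this assay, at which 2 of the 4 values shown sit. Both non-aromatic rings tried on the amine nitrogen, cyclopropyl and cyclohexyl, therefore end at that limit, and the step between them cannot be read. In this assay the swap of benzyl for cyclohexyl gives an at least 1.4-fold higher number from compound 3 to compound 4 (0.16 log units; that floor lies within the scatter), a floor too small to separate the two groups, whereas the swap of 4-bromophenyl for cyclohexyl gives an at least 3.0-fold higher number from compound 1 to compound 4 (0.48 log units; beyond the scatter), which is the firmer result.

Going by these compounds, how much weaker the two compounds at the limit really are stays unknown. On these data alone, it also remains open whether the bromine matters or only an aromatic ring set directly on the nitrogen, and a plain phenyl or a 4-methoxyphenyl group there would help to tell these apart.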